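This account rests on a few compounds, and the source may have more. Where it says the series, first, only, none or still open, it means among the compounds named here.

Compound 1 `CC(C)(C)c1ncc(C#Cc2ccccc2)cn1` was tested in an assay on HEK293 cells for positive allosteric modulation of metabotropic glutamate receptor 5 (Rattus norvegicus) (on this read-out higher numbers stand for an effect only at larger amounts of compound and lower numbers for an effect already at smaller amounts), and gives 247000 nM. Among the two compounds with a result in this assay, compound 1 holds the only number; compound 2 `Cc1ccc(C#Cc2cnc(C(C)(C)C)nc2)cc1` is reported in this assay as "not active" (no number reported), without a number. Compound 3 `COc1ncc(C#Cc2ccccc2)cn1` has not yet been measured. It differs from compound 1 in one place: methoxy in place of tert-butyl on an aromatic carbon. Within the data shown here, no step between two measured compounds is available to guide a forecast here, and a value as high as that of compound 1 leaves little room for a further weakening to still come out as a number. The expected step is a 1.2-fold higher number from compound 1 to compound 3 (0.08 log units; within the scatter), which would sit within the usual scatter, with a real chance that compound 3 is reported without a number at all. Compound 3 is estimated at 300000 nM, with a range from 80000 nM to 1000000 nM.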

Compound 3, half-maximal effective concentration: "not active" (no number reported)
Nothing numeric was reported for compound 3; there is nothing to compare the estimate with.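

Among these compounds, compound 3 is reported as "not active" without a number in this assay, and no step from compound 1 to compound 3 can be read. No measurement shown offers an explanation for this result. The compounds shown leave open how large the effect of replacing tert-butyl with methoxy is.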